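A few compounds are considered here, and "the series" means these few. Any claim that something is new, unique, unknown or untested is made for them only; others in the source may bear on it.

Measured compounds:
compound 1 `Cc1ccc(Nc2ccc3c(c2)C(=O)N(C2CCC(=O)NC2=O)C3=O)cc1` — 5%
compound 2 `O=C1CCC(N2C(=O)c3ccc(Nc4ccc(O)cc4)cc3C2=O)C(=O)N1` — 4%
compound 3 `CCc1ccc(Nc2ccc3c(c2)C(=O)N(C2CCC(=O)NC2=O)C3=O)cc1` — 5%

All three values come from an assay on FRT-Jurkat cells for inhibition of nuclear factor NF-kappa-B complex (Homo sapiens), read by flow cytometry, with a stated time of 24 h, tested at 10 uM; a lower number here means less inhibition, a higher number more inhibition at the concentration tested (going by the name of the read-out). Compound 3 stands level with compound 1, and compound 2 sits within the scatter of both; nothing separates the three beyond the usual run of repeats.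

Compound 4 `CC(=O)c1ccc(Nc2ccc3c(c2)C(=O)N(C2CCC(=O)NC2=O)C3=O)cc1` is the next entry. acetyl in place of ethyl on an aromatic carbon

Going by the values given here, the steps that bear on this position are a number 1 percentage points lower from compound 1 to compound 2 (within the scatter) and a number 1 percentage points higher from compound 2 to compound 3 (within the scatter): swapping methyl, hydroxy or ethyl on that aromatic carbon has moved nothing beyond the scatter. Among the compounds with values here, an acetyl group brings one hydrogen-bond acceptor, but the hydroxy of compound 2 also brought one and gave no step. Expected for compound 4, therefore, is no change at the digits printed from compound 3 to compound 4 (within the scatter), no movement beyond the scatter.

Estimate for compound 4 in this assay: 5%, range 0% to 12%.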

Compound 4, a percentage reported as inhibition, at one concentration (the size of the read-out at that concentration, not a potency): -2%
Compound 4: middle estimate off by 7 percentage points, on the high side, and the stated range ends above it.
By their numbers in this assay, from the lowest: compounds 4, 2, 1 and 3 (each within the scatter of the next).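

Acetyl on this aromatic carbon gives a number 7 percentage points lower from compound 3 to compound 4 (within the scatter) and a number 6 percentage points lower from compound 2 to compound 4 (within the scatter) and also a number 7 percentage points lower from compound 1 to compound 4 (within the scatter) as the third comparison. The position therefore now takes a group with a carbonyl, as well as methyl, hydroxy and ethyl, and all of these steps stay inside the scatter, so the four compounds form one undivided set. No measurement here accounts for where these numbers sit. From the compounds shown here alone, whether an amine, a carboxylic acid or a longer chain at this place would give a number clear of this set remains open.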